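Changing the group on the carbonyl of compound 3

This account rests on a few compounds, and the source may have more. Where it says the series, first, only, none or still open, it means among the compounds named here.

In a functional assay on the whole organism for inhibition, with Mus musculus as the target (on this read-out higher numbers stand for an effect only at larger amounts of compound and lower numbers for an effect already at smaller amounts), compound 1 `Cc1ccc(C2CN(C)Cc3c(N)cccc32)cc1` gives 1.6 mg/kg as its result. Compound 2 `CC(C)c1ccc(C2CN(C)Cc3c(N)cccc32)cc1` gives > 80 mg/kg as its result, which is a limit of the assay and not a number. Compound 3 `CCNC(=O)Nc1cccc2c1CN(C)CC2c1ccccc1` gives 80 mg/kg as its result. That is the higher of the two actual numbers, far beyond the scatter from the number of compound 1.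

Compound 4 `CCNCC(=O)Nc1cccc2c1CN(C)CC2c1ccccc1` has not been measured. It carries (ethylamino)methyl in place of ethylamino on a carbonyl carbon.

For the measured compounds named here, the one measured step is an at least 50-fold higher number from compound 1 to compound 2 (1.69 log units; beyond the scatter) and it was large. It lies on an aromatic carbon, however, not on the carbonyl. It suggests that a small change can matter among these compounds, but it gives no direction for compound 4. Results in this assay also stop at the limit of > 80 mg/kg in this assay, at which 1 of the 3 values shown sits, and that is only a limit. With compound 3 at 80 mg/kg there is little room upward, so a moderate fall is the likelier change that could be read as a number.

The expected change is a 2.7-fold lower number from compound 3 to compound 4 (0.43 log units; beyond the scatter) and it remains uncertain. For compound 4 the estimate is 30 mg/kg with an expected range from 5 mg/kg to 120 mg/kg in this read-out.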

Compound 4, dose for half-maximal effect: 47 mg/kg
Beside the measured number, compound 4's estimate is 1.6-fold (0.19 log units) below it; low and high end bracket the measured number.
By their numbers in this assay, from the lowest: compound 1; then compounds 4 and 3 (each within the scatter of the next).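

In this assay, the first change measured on the carbonyl carbon gives a 1.7-fold lower number from compound 3 to compound 4 (0.23 log units; within the scatter), so ethylamino and (ethylamino)methyl cannot be told apart at this position. The only earlier step, an at least 50-fold higher number from compound 1 to compound 2 (1.69 log units; beyond the scatter), lay on an aromatic carbon, and it showed that a small change can have a large effect among these compounds; the swap on the carbonyl carbon shows that not every small change does, at least for this pair of groups. The reading comes with a caution, since compound 3 gives 80 mg/kg and compound 4 gives 47 mg/kg, so neither number lies far from the top of what this assay can report as a number: the limit of > 80 mg/kg in this assay, at which 1 of the 4 values shown sits.

With only two groups shown on this carbonyl carbon, it remains open whether a longer chain, a hydroxyl group or a carboxylic acid in the same place would move the number clearly beyond the scatter from compound 3. For the compounds shown here, it is also open whether this insensitivity would hold on a core carrying another aromatic group, such as the one in compound 1.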